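Cyclopropylmethoxy in place of methoxy: cytotoxicity on Vero cells

The source may report more compounds than this note shows. Statements on the series, on what has been measured and on what is new or still open speak of the compounds shown alone.

Compound 1, `Fc1ccc(-c2nn3c(NC4CCCC4)cccc3c2-c2ccnc(NC3CCCC3)n2)cc1`, in an ADME assay on Vero cells (Chlorocebus sabaeus) for cytotoxicity (a lower number here means that less compound is tolerated, a higher number that more compound is tolerated), gives a limit of > 160000 nM.
Compound 2, `c1cc(-c2c(-c3ccc(OCC4CC4)cc3)nn3ccc(NC4CCCC4)cc23)nc(NC2CCCC2)n1`, in this assay gives a limit of > 40000 nM.
Compound 3, `COc1ccc(-c2nn3c(NC4CCCC4)cccc3c2-c2ccnc(NC3CCCC3)n2)cc1`, in this assay gives a limit of > 100000 nM.

All three of these values are limits of the assay rather than numbers, so compound 3 stands, like its two neighbours, at the edge of what this assay can report, and nothing on the numbers shown separates it from compound 1 or compound 2. Among the compounds with values here, the one measured step, a step that the two limits leave unreadable from compound 1 to compound 3, cannot be sized, because both of its ends are limits (the limit of > 160000 nM in this assay, at which 1 of the 3 values shown sits, and (the limit of > 100000 nM in this assay, at which 1 of the 3 values shown sits)). The step to compound 4, `c1cc(NC2CCCC2)n2nc(-c3ccc(OCC4CC4)cc3)c(-c3ccnc(NC4CCCC4)n3)c2c1`, is cyclopropyl in place of hydrogen on a saturated chain carbon bound to an oxygen on an aromatic ring. No measured step bears on this change directly; what the record offers is that every compound shown, compound 2 among them, which carries the same cyclopropylmethoxy group on a differently arranged core, sits at a limit (the limit of > 40000 nM in this assay, at which 1 of the 3 values shown sits). The writer therefore expects no step beyond the scatter in this assay and expects compound 4 to return a limit again, the estimated step being a number no higher from compound 3 to compound 4 (the limit leaves the size open). Compound 4 is estimated at 100000 nM, with a range from 30000 nM to 300000 nM.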

Compound 4, half-maximal cytotoxic concentration: > 40000 nM
Compound 4 was reported as a limit; the forecaster's own chance of this, stated with the estimate: 75%; the middle value is on the limit's open side.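

In this assay compound 4 is reported only as a limit, as are compound 3 and compound 1, so neither the step from compound 3 to compound 4 nor the step from compound 1 to compound 4 can be read. The compounds shown leave open whether methoxy to cyclopropylmethoxy changes tolerance at all in this assay and what concentration any of them would need to reach half-maximal cytotoxicity.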